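Aryl Swap on Compound 1: Dimethoxyphenyl to Furan

The compounds below may be only part of what the source reports. "The series", "measured", "known", "first", "only" and "open" are said of these compounds alone.

Compound 1 `CCOC(=O)c1cnn(-c2nc(-c3cccc(OC)c3OC)c(C#N)c(=O)n2C)c1N` gives 54 ug/mL in a functional assay, with a stated time of 20 min; on this read-out lower numbers stand for stronger inhibition and higher numbers for weaker inhibition. Compound 2 `CSc1nc(-c2ccccc2O)c(C#N)c(=O)n1C` gives 52 ug/mL and compound 3 `COc1cccc(-c2nc(NN)n(C)c(=O)c2C#N)c1OC` gives 44 ug/mL, so the three numbers lie within the scatter of one another and compound 1 stands level with the others rather than apart. Compound 4 `CCOC(=O)c1cnn(-c2nc(-c3ccco3)c(C#N)c(=O)n2C)c1N` differs from compound 1 by furan-2-yl in place of 2,3-dimethoxyphenyl on an aromatic carbon. Among the measured compounds shown here, no measured pair traces this change. The three compounds differ considerably in their groups yet return numbers within the scatter of one another, so no step beyond the scatter is expected in this assay in either direction. Compound 4 is expected at 55 ug/mL, with a range from 25 ug/mL to 120 ug/mL. The expected step is a 1.0-fold higher number from compound 1 to compound 4 (0.01 log units; within the scatter).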

Compound 4, half-maximal inhibitory concentration: 91 ug/mL
For compound 4 the middle estimate is 1.7-fold (0.22 log units) below the measured one; the measured number falls inside the stated range.
By their numbers in this assay, from the lowest: compounds 3, 2, 1 and 4 (each within the scatter of the next, the first and the last beyond it).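

Among the compounds shown here, this is the first single-change pair. In this assay, furan-2-yl in place of 2,3-dimethoxyphenyl, on the aromatic carbon ortho to a cyano group, gives a step that stays within the scatter (a 1.7-fold higher number from compound 1 to compound 4 (0.23 log units; within the scatter)), so this position tolerates the five-membered ring in this one pair. No supporting data bear on this result.

As far as these compounds go, whether an unsubstituted phenyl, a pyridine or a morpholine at this position would give a step beyond the scatter remains open. So does whether furan-2-yl behaves alike alongside the other groups of compound 2 and compound 3.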